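Dimethylamino on the Benzamide of Compound 2

The source may hold more compounds than are shown below. What is called first, only, known or untested is meant among the compounds shown, and "the series" means these compounds.

Compound 1 `CC1(C)c2[nH]nc(NC(=O)c3ccccc3)c2CN1Cc1cccc(I)c1` gives 1360 nM in an assay on Sf21 cells for inhibition of high affinity nerve growth factor receptor (Homo sapiens), read by HTRF, with a stated time of 30 min, in the presence of a further agent that is not named here; on this read-out lower numbers stand for stronger inhibition and higher numbers for weaker inhibition.
Compound 2 `CC1(C)c2[nH]nc(NC(=O)c3ccccc3)c2CN1Cc1cccc(F)c1F` gives 200 nM in this assay.
Compound 3 `CC1(C)c2[nH]nc(NC(=O)c3ccccc3)c2CN1Cc1ccc(F)c(F)c1` gives 680 nM in this assay.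

Among these three, compound 2 holds the lowest number; the steps of a 6.8-fold lower number from compound 1 to compound 2 (0.83 log units; beyond the scatter) and a 3.4-fold higher number from compound 2 to compound 3 (0.53 log units; beyond the scatter) both lie beyond the scatter, while a 2.0-fold lower number from compound 1 to compound 3 (0.30 log units; within the scatter) lies within it. Compound 4 `CN(C)c1ccc(C(=O)Nc2n[nH]c3c2CN(Cc2cccc(F)c2F)C3(C)C)cc1` differs from compound 2 by dimethylamino in place of hydrogen on an aromatic carbon. Among the measured compounds shown here, every measured step changes the group on the saturated chain carbon bound to the amine nitrogen; none alters the benzamide phenyl, so no measured step bears on this change. The expected step is therefore no change at the digits printed from compound 2 to compound 4 (within the scatter), none beyond the scatter. Compound 4 is estimated at 200 nM, with a range from 60 nM to 700 nM.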

Compound 4, half-maximal inhibitory concentration: 69 nM
Estimate against measurement, compound 4: 2.9-fold (0.46 log units) above, and the stated range covers the measured number.
By their numbers in this assay, from the lowest: compound 4; then compound 2; then compounds 3 and 1 (each within the scatter of the next).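

Among the compounds shown here, the benzamide phenyl, left unchanged across the earlier compounds, turns out to affect the number in this assay: with 2,3-difluorophenyl held constant, dimethylamino in place of hydrogen gives a 2.9-fold lower number from compound 2 to compound 4 (0.46 log units; beyond the scatter), placing compound 4 lowest of the four. Nothing shown accounts for this step.

On these data alone, it remains open whether another group at this place, such as methoxy, a morpholine ring or a plain amine, would match dimethylamino. Whether the same change would carry over to compound 1 or compound 3 is also unsettled.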